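The source may hold more compounds than are shown below. What is called first, only, known or untested is meant among the compounds shown, and "the series" means these compounds.

Compound 1 `COc1ccc(-c2sc(N)c(C(=O)c3ccc(Cl)cc3)c2C)cc1`: 1%
Compound 2 `CC(C)(C)Cc1c(-c2cccc(F)c2F)sc(N)c1C(=O)c1ccc(Cl)cc1`: 1%
Compound 3 `CC(C)(C)Cc1csc(N)c1C(=O)c1cccc(C(F)(F)F)c1`: 1%

All three were tested in an assay on CHO cells for displacement of a labelled ligand from adenosine receptor A3 (Homo sapiens), read by scintillation counting, tested at 10 uM; a lower number here means less inhibition, a higher number more inhibition at the concentration tested (going by the name of the read-out). Compound 2 gives 1%, level with compound 1 at 1% and with compound 3 at 1%; these differences lie within the scatter, so none of the three stands apart from the others.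

Compound 4 `CC(C)(C)Cc1c(Br)sc(N)c1C(=O)c1ccc(Cl)cc1` has not yet been measured. It differs from compound 2 in one place: bromo in place of 2,3-difluorophenyl on an aromatic carbon. Among the compounds with values here, no measured pair shows the effect of such a change, so there is no yardstick for its size. The measured compounds all read low, and nothing shown points to a rise. The step of a number 1 percentage points higher from compound 2 to compound 4 (within the scatter) is therefore expected to stay within the scatter. Compound 4 is expected to give about 2%, between -6% and 12%.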

Compound 4, a percentage reported as inhibition, at one concentration (the size of the read-out at that concentration, not a potency): 1%
Beside the measured number, compound 4's estimate is 1 percentage points above it; measured number inside the range.
By their numbers in this assay, from the lowest: compounds 1, 2, 3 and 4 (each within the scatter of the next).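

Putting bromo in place of 2,3-difluorophenyl on the aromatic carbon next to the ring sulfur brings no change at the digits printed from compound 2 to compound 4 (within the scatter) in this assay. Removing a whole aromatic ring from this position therefore leaves the reading where it was, but both compounds sit near the bottom of the scale, so the pair cannot show whether this position matters. Nothing measured here offers an explanation for the result.

Going by these compounds, whether any group on this carbon can raise the inhibition remains open. An amine or a carboxylic acid there would test this against compound 4.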